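Adding a Second Chloro to the Phenyl of Compound 1

A few compounds are considered here, and "the series" means these few. Any claim that something is new, unique, unknown or untested is made for them only; others in the source may bear on it.

The measured compounds:
- compound 1 `CC(C)(C)n1ncc(OCc2nnc(-c3ccccc3Cl)o2)c(Cl)c1=O`: 3.19
- compound 2 `CC(C)(C)n1ncc(OCc2nnc(-c3ccc(Cl)cc3)o2)c(Cl)c1=O`: 3.09
- compound 3 `COc1ccc(-c2nnc(COc3cnn(C(C)(C)C)c(=O)c3Cl)o2)cc1`: 3.52

In a physicochemical assay for lipophilicity (a lower number here means a more polar compound, a higher number a more lipophilic compound), compound 1 gives 3.19, the second highest of the three numbers. The nearest is a number 0.10 log units lower from compound 1 to compound 2 (within the scatter), and the furthest is a number 0.33 log units higher from compound 1 to compound 3 (beyond the scatter). Compound 2 and compound 3 differ from each other by a number 0.43 log units higher from compound 2 to compound 3 (beyond the scatter).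

Compound 4 `CC(C)(C)n1ncc(OCc2nnc(-c3ccc(Cl)cc3Cl)o2)c(Cl)c1=O` has not yet been measured. It differs from compound 1 by chloro in place of hydrogen on an aromatic carbon, which, cut one bond further out, reads 2-chlorophenyl to 2,4-dichlorophenyl. Among the measured compounds shown here, none of the measured steps exchanges hydrogen for chloro; the closest is a number 0.10 log units lower from compound 1 to compound 2 (within the scatter), which moved a single chloro and stayed within the scatter, and a number 0.43 log units higher from compound 2 to compound 3 (beyond the scatter), which swapped chloro for methoxy and rose modestly. Adding a chloro while keeping the first one is expected to raise the number in this assay by a modest to medium step, estimated as a number 0.56 log units higher from compound 1 to compound 4 (beyond the scatter). Compound 4 is therefore estimated at 3.75, with a range from 3.35 to 4.15.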

Compound 4, partition coefficient: 3.52
For compound 4 the middle estimate is 0.23 log units above the measured one; low and high end bracket the measured number.
By their numbers in this assay, from the lowest: compounds 2 and 1 (each within the scatter of the next); then compounds 3 and 4 (each within the scatter of the next).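

In this assay, among the compounds shown here, hydrogen gives way to chloro on the phenyl for the first time, at the carbon para to a large group, and the first chloro stays in place: this gives a number 0.33 log units higher from compound 1 to compound 4 (beyond the scatter). The same kind of exchange, starting from the 4-chlorophenyl group, gives a number 0.43 log units higher from compound 2 to compound 4 (beyond the scatter), so in both available pairs the second chloro raises the number and neither goes against this. Putting 2,4-dichlorophenyl in place of 4-methoxyphenyl gives no change at the digits printed from compound 3 to compound 4 (within the scatter), so the two groups cannot be told apart in this assay.

Nothing shown accounts for the size or direction of these steps. On these data alone, whether an amine or a carboxylic acid at this same carbon would lower the number, or a third chloro would raise it further, remains open.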